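The compounds below may be only part of what the source reports. "The series", "measured", "known", "first", "only" and "open" are said of these compounds alone.

Compound 1 `CCCCCCOc1ccc2c(Cl)ccnc2c1` gives, in a functional assay on BGC-823 cells (Homo sapiens) for cytotoxicity, read by MTT assay, with a stated time of 48 h (on this read-out lower numbers stand for stronger inhibition and higher numbers for weaker inhibition), a reading of 2380 nM, the highest of the three numbers recorded. Compound 2 `Clc1ccnc2cc(OCCc3ccccc3)ccc12` gives 2010 nM in this assay, and compound 3 `CCCCCCOc1ccc2c(NCCN(C)C)ccnc2c1` gives 1090 nM. The step to compound 4 `C=CCOc1ccc2c(Cl)ccnc2c1` is vinyl in place of pentyl on a saturated chain carbon bound to an oxygen on an aromatic ring, the same difference, cut one bond further out, reading hexyl to allyl. Of the measured steps, only the change on the chain bears on it: a 1.2-fold lower number from compound 1 to compound 2 (0.07 log units; within the scatter). The step of a 2.2-fold lower number from compound 1 to compound 3 (0.34 log units; beyond the scatter) concerns the chloro and does not inform this change. A shortened chain is therefore expected to give no step beyond the scatter, a 1.2-fold higher number from compound 1 to compound 4 (0.07 log units; within the scatter). Compound 4 is estimated at 2800 nM, within 1100 nM to 7500 nM.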

Compound 4, half-maximal inhibitory concentration: 2930 nM
Compound 4: the middle estimate sits 1.0-fold (0.02 log units) below what was measured; the range from low to high includes it.
By their numbers in this assay, from the lowest: compounds 3, 2, 1 and 4 (each within the scatter of the next, the first and the last beyond it).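

In this assay, vinyl in place of pentyl on a saturated chain carbon bound to an oxygen on an aromatic ring gives a 1.2-fold higher number from compound 1 to compound 4 (0.09 log units; within the scatter) and so stays within the scatter. Losing carbons from the hexyl chain and adding a double bond therefore moved the reading no further than the phenyl of compound 2 did. No evidence bears on this result.

Still open, going by these compounds, is whether an amine or a carboxylic acid on that chain would step beyond the scatter. Also open, on these data alone, is whether allyl would behave alike with the (2-(dimethylamino)ethyl)amino group of compound 3 in place of chloro.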